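This account rests on a few compounds, and the source may have more. Where it says the series, first, only, none or still open, it means among the compounds named here.

Two members of the series have numbers in a functional assay on L1210 cells (Mus musculus) for inhibition, read by thymidine incorporation, with a stated time of 3 h; a higher number here means that more compound is needed for the effect, a lower number that less compound is needed. Compound 1 `CCCCCCCCCCCC(=O)NCC(=O)N[C@@H]1[C@@H](O)[C@H](O)[C@@H](Nc2ncnc3[nH]cnc23)O[C@H]1C` gives 29 uM. Compound 2 `CCCCCC(=O)NCC(=O)N[C@@H]1[C@@H](O)[C@H](O)[C@@H](Nc2ncnc3[nH]cnc23)O[C@H]1C` reaches only the limit of the measurement, recorded as > 1000 uM (the limit of > 1000 uM in this assay, at which 1 of the 2 values shown sits), so compound 2 stands at the weak end of the numbers shown. The shortening of the acyl chain gave an at least 34-fold higher number from compound 1 to compound 2 (1.53 log units; beyond the scatter). Compound 3 `CC(C)CCCCCCCCCCCCC(=O)NCC(=O)N[C@@H]1[C@@H](O)[C@H](O)[C@@H](Nc2ncnc3[nH]cnc23)O[C@H]1C` is not yet measured; it differs from compound 2 by 8-methylnonyl in place of hydrogen on a saturated chain carbon, five bonds along the chain from a carbonyl carbon. The change runs the other way and further than the hexyl removal in an at least 34-fold higher number from compound 1 to compound 2 (1.53 log units; beyond the scatter), so a large step toward a lower number in this assay is expected, an at least 66-fold lower number from compound 2 to compound 3 (1.82 log units; beyond the scatter). Compound 3 is estimated at 15 uM, within 4 uM to 60 uM.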

Compound 3, concentration for half-maximal effect: 1.8 uM
Compound 3: middle estimate off by 8.3-fold (0.92 log units), on the high side; measured number below the stated range.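

In this assay, growth at the saturated chain carbon five bonds along the chain from a carbonyl carbon keeps paying beyond hexyl: 8-methylnonyl in place of hydrogen gives an at least 550-fold lower number from compound 2 to compound 3 (2.74 log units; beyond the scatter). The trend had not levelled off with hexyl: isobutyl in place of hydrogen on a saturated chain carbon gives a 16-fold lower number from compound 1 to compound 3 (1.21 log units; beyond the scatter). The value of compound 2 is a limit, so the true size of the first step stays unknown: the limit of > 1000 uM in this assay, at which 1 of the 3 values shown sits.

Open, on these data alone, are the effect of a longer chain and of a straight chain in place of the branched end. Also open, as far as these compounds go, is how a carboxylic acid or an amine at the chain end would read.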